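Aryl exchange at the imine carbon: outlook for compound 4

A few compounds are considered here, and "the series" means these few. Any claim that something is new, unique, unknown or untested is made for them only; others in the source may bear on it.

Measured so far:
compound 1 `COc1cc(C2CC(c3ccc([N+](=O)[O-])cc3)=NN2C(C)=O)ccc1OCc1cn(Cc2ccc([N+](=O)[O-])cc2)nn1` gives 7% in a functional assay on THP-1 cells (Homo sapiens) for inhibition, read by sulforhodamine B assay, tested at 10 uM; a lower number here means less inhibition of growth, a higher number more inhibition of growth at the concentration tested
compound 2 `COc1cc(C2CC(c3ccc(Br)cc3)=NN2C(C)=O)ccc1OCc1cn(Cc2ccc([N+](=O)[O-])cc2)nn1` gives 1% in this assay
compound 3 `COc1ccc(C2=NN(C(C)=O)C(c3ccc(OCc4cn(Cc5ccc([N+](=O)[O-])cc5)nn4)c(OC)c3)C2)cc1` gives 8% in this assay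

All three share one core and differ only in the group on a carbon with a double bond to nitrogen. The steps there are small: a number 6 percentage points lower from compound 1 to compound 2 (within the scatter), a number 1 percentage points higher from compound 1 to compound 3 (within the scatter) and a number 7 percentage points higher from compound 2 to compound 3 (within the scatter), each within the scatter. Compound 3 carries the top number of the three, but its separation from compound 1 and from compound 2 is not beyond the scatter, so the three values read as one level of weak inhibition.

Compound 4 `COc1cc(C2CC(c3cccc4ccccc34)=NN2C(C)=O)ccc1OCc1cn(Cc2ccc([N+](=O)[O-])cc2)nn1` differs from compound 3 by naphthalen-1-yl in place of 4-methoxyphenyl on a carbon with a double bond to nitrogen. The three measured steps bear on this change, since each varies the group on the same carbon, and none of them moved the read-out beyond the scatter. Going by the values given here, no measured step involves a bicyclic group, so that part is unknown. The expectation for this assay is therefore no step beyond the scatter, in either direction.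

Compound 4 is expected to give 8%, in the range -5% to 22%. The expected step is no change at the digits printed from compound 3 to compound 4 (within the scatter).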

Compound 4, percent growth inhibition at one concentration: 10%
Beside the measured number, compound 4's estimate is 2 percentage points below it; the measured number falls inside the stated range.
By their numbers in this assay, from the lowest: compounds 2, 1, 3 and 4 (each within the scatter of the next).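

In this assay, going by these compounds alone, the first bicyclic group at this position, naphthalen-1-yl, gives a number 2 percentage points higher from compound 3 to compound 4 (within the scatter), a number 9 percentage points higher from compound 2 to compound 4 (within the scatter) and a number 3 percentage points higher from compound 1 to compound 4 (within the scatter). The carbon with a double bond to nitrogen therefore accepts two six-membered aromatic rings of carbon only, and a group with no hydrogen-bond acceptor, while all four compounds stay at one level of weak inhibition. Nothing available accounts for this flat read-out.

Still open, on these data alone, is whether any group at this carbon can move the read-out beyond the scatter, for example an amine such as piperidine, a carboxylic acid, or a longer alkyl chain in place of the aryl group. The compounds shown also leave open whether changes elsewhere on the shared core would matter more than this exchange.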